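The source may report more compounds than this note shows. Statements on the series, on what has been measured and on what is new or still open speak of the compounds shown alone.

Compound 1 `ClCc1ccc(Cn2cnc3c(Cl)ncnc32)cc1` and compound 2 `ClCc1cccc(Cn2cnc3ncnc(Cl)c32)c1` share the same atoms joined differently; how their two cores differ is not broken down here. In a functional assay on 786-0 cells (Homo sapiens) for cytotoxicity, read by sulforhodamine B assay, with a stated time of 48 h (a lower number here means that less compound is tolerated, a higher number that more compound is tolerated), compound 1 gives 21400 nM, while compound 2 gives 70800 nM. Within the data shown here, compound 3 `ClCc1ccc(Cn2cnc3c(Cl)nc(Cl)nc32)cc1` follows from compound 1 by one change, (chloro in place of hydrogen on an aromatic carbon), and in this assay compound 3 gives 61700 nM; the step of a 2.9-fold higher number from compound 1 to compound 3 (0.46 log units; beyond the scatter) is the only measured example of this change. Compound 4 `ClCc1cccc(Cn2cnc3nc(Cl)nc(Cl)c32)c1`, not yet measured, carries the same change on the core of compound 2, (chloro in place of hydrogen on an aromatic carbon), at a place described in the same words as for compound 3. The values of compound 2 and compound 3 lie within the scatter of each other, so nothing is said about their order. Because the step of a 2.9-fold higher number from compound 1 to compound 3 (0.46 log units; beyond the scatter) was beyond the scatter, a step of similar size is expected from compound 2 to compound 4, a 2.4-fold higher number from compound 2 to compound 4 (0.38 log units; beyond the scatter), and compound 4 is estimated in this assay at 170000 nM, between 75000 nM and 380000 nM.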

Compound 4, concentration lethal to 50% of the cells: 5370 nM
Compound 4: the middle estimate sits 32-fold (1.50 log units) above what was measured, outside the stated range (below it).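

In this assay, the chloro in place of hydrogen on an aromatic carbon gives a 13-fold lower number from compound 2 to compound 4 (1.12 log units; beyond the scatter), and so the change does not carry over from one core to the other with the same size or direction: the same change on two cores in this assay, a 2.9-fold higher number (0.46 log units; beyond the scatter) from compound 1 to compound 3 and a 13-fold lower number (1.12 log units; beyond the scatter) from compound 2 to compound 4, 38-fold (1.58 log units) apart, beyond the scatter of two such steps. In this series, then, the result of this change could not be read across from the core of compound 1 to the core of compound 2, and the outcome on one core gave no safe guide to the outcome on the other. Among these compounds, this rests on only two pairs, however, and it shows neither why the two steps part nor how the change would behave on any further core.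

The compounds shown leave open whether an amine or a methoxy group on the same aromatic carbon between two ring nitrogen atoms would also give opposite results on the two cores. They also leave open whether the split between the cores would persist with a hydroxymethyl group in place of the chloromethyl group.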